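Oxazoline to thiazoline on the sulfonylmethyl arm

A few compounds are considered here, and "the series" means these few. Any claim that something is new, unique, unknown or untested is made for them only; others in the source may bear on it.

Two measured compounds frame the series. Compound 1 `Cc1ccc(C2CNN=C2S(=O)(=O)CC2=NCCS2)cc1` gives 39.8% in a functional assay, tested at 50 ug/mL; on this read-out higher numbers stand for a stronger effect at the one concentration tested and lower numbers for a weaker effect. Compound 2 `O=S(=O)(CC1=NCCO1)C1=NNCC1c1ccccc1`, which carries the oxazoline arm and an unsubstituted phenyl, is recorded in this assay as "not active" (no number reported), so no number places it on the scale; it stands only as the weaker of the two measured compounds.

Compound 3 `O=S(=O)(CC1=NCCS1)C1=NNCC1c1ccccc1` is the next step from compound 2. The change is a group of 5 heavy atoms (3 carbon, 1 nitrogen, 1 sulfur; one five-membered non-aromatic ring with 2 hetero atoms) in place of a group of 5 heavy atoms (3 carbon, 1 nitrogen, 1 oxygen; one five-membered non-aromatic ring with 2 hetero atoms), on a saturated chain carbon bound to a sulfonyl sulfur; the place is on a saturated chain carbon bound to a sulfonyl sulfur. Compound 3 thereby shares the thiazoline arm of compound 1 and differs from it only at the phenyl ring. For the measured compounds named here, no measured pair isolates this change, so the step in this assay is expected to be upward, but its size is uncertain. Compound 3 is estimated to give 30% in this assay, within 5% to 55%.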

Compound 3, a percentage reported as activity, at one concentration (the size of the read-out at that concentration, not a potency): "not active" (no number reported)
No number was reported for compound 3; there is nothing to compare the estimate with.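

No new step can be read, since compound 2 and compound 3 both stand as "not active" in this assay with no number. No measurement on hand bears on this result. The compounds shown leave open whether compound 1 at 39.8% owes that value to its difference from compound 3 at the phenyl ring.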